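This account rests on a few compounds, and the source may have more. Where it says the series, first, only, none or still open, it means among the compounds named here.

Compound 3 `COc1ccc(CN2CCc3nc(-c4ccccn4)nc(NCCCn4ccnc4)c3C2)cc1` stands lowest of the three compounds measured in an assay on FRT cells with Cystic fibrosis transmembrane conductance regulator variant F508del (Homo sapiens) as the target, read by fluorescence, with a stated time of 25 min; on this read-out higher numbers stand for larger maximal responses and lower numbers for smaller maximal responses: compound 3 gives 40.6%. Its nearest neighbour on that scale is compound 1 `NC(=O)CN1CCN(c2nc(-c3ccccn3)nc3c2CN(Cc2ccccc2)CC3)CC1`, which in this assay gives 57.9%, and the furthest is compound 2 `COc1ccc(CN2CCc3nc(-c4ccccn4)nc(N4CCC(C(N)=O)CC4)c3C2)cc1`, which gives 86.6%. Compound 4 `COc1ccc(CN2CCc3nc(-c4ccccn4)nc(N4CCN(CC(N)=O)CC4)c3C2)cc1` has not yet been measured; it differs from compound 3 in one place, (4-(carbamoylmethyl)piperazin-1-yl in place of (3-(1H-imidazol-1-yl)propyl)amino on an aromatic carbon).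

Among the measured compounds shown here, one measured step bears on this change. Going a number 46 percentage points lower from compound 2 to compound 3 (beyond the scatter), the swap of a ring amine carrying an amide for (3-(1H-imidazol-1-yl)propyl)amino cost a large amount; compound 4 takes the opposite route, replacing that chain with a ring amine that again carries an amide. Compound 1 carries the same 4-(carbamoylmethyl)piperazin-1-yl group as compound 4 but differs from compound 3 in a second place as well, so its value can only be read as a loose pointer. Compound 4 is therefore expected to rise beyond the scatter, by a number 25.4 percentage points higher from compound 3 to compound 4 (beyond the scatter), toward the region between compound 1 and compound 2. The estimate for compound 4 in this assay is 66%, with a likely range from 48% to 84%.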

Compound 4, largest response reached (Emax), in percent of the reference or control that the assay uses in the Cystic fibrosis transmembrane conductance regulator assay: 35.9%
For compound 4 the middle estimate is 30.1 percentage points above the measured one, outside the stated range (below it).
By their numbers in the Cystic fibrosis transmembrane conductance regulator assay, from the lowest: compounds 4 and 3 (each within the scatter of the next); then compound 1; then compound 2.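

In the Cystic fibrosis transmembrane conductance regulator assay a ring amine carrying an amide does not by itself bring back the response at this position: a number 4.7 percentage points lower from compound 3 to compound 4 (within the scatter) separates 4-(carbamoylmethyl)piperazin-1-yl from (3-(1H-imidazol-1-yl)propyl)amino by no more than the scatter, while a number 50.7 percentage points lower from compound 2 to compound 4 (beyond the scatter) shows that the two amide-bearing ring amines are far from interchangeable on this aromatic carbon. With 4-(carbamoylmethyl)piperazin-1-yl held in place, the second point of difference also counts, for a number 22 percentage points lower from compound 1 to compound 4 (beyond the scatter) comes with methoxy in place of hydrogen on an aromatic carbon. In a physicochemical assay for solubility, read by HPLC, with a stated time of 24 h, at pH 7.4, tested at 250 uM (on this read-out higher numbers stand for higher solubility and lower numbers for lower solubility), compound 3 gives 217000 nM and compound 4 gives 217000 nM, which is no change at the digits printed from compound 3 to compound 4 (within the scatter) and shows that this change leaves that read-out where it stands.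

Nothing shown here accounts for these differences. The compounds shown also leave open whether the gap between compound 2 and compound 4 follows the ring itself or the link to the amide, since both change together, and a piperidine ring carrying a carbamoylmethyl group would be needed to separate the two.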